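The source may report more compounds than this note shows. Statements on the series, on what has been measured and on what is new or still open speak of the compounds shown alone.

Working notes on the series. The shared core, the methyl ester on an oxirane ring, is carried by compound 1 `CCCCCCC1(C(=O)OC)CO1`, compound 2 `CCCCCCCCCCCCCCC1(C(=O)OC)CO1` and compound 3 `CCCCCCCCCCCC1(C(=O)OC)CO1`, which differ only in the length of the saturated chain. In a functional assay on the whole organism with Rattus norvegicus as the target, in the glucose tolerance test (a higher number here means that more compound is needed for the effect, a lower number that less compound is needed), compound 1 gives 10 mg/kg, compound 2 gives 4 mg/kg and compound 3 gives 10 mg/kg. Compound 3 thus stands level with compound 1 at the highest number of the three, while compound 2 sits at a lower number, beyond the scatter.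

The next compound, compound 4 `CCCCCCCCCCC1(C(=O)OC)CO1`, differs from compound 3 by hydrogen in place of methyl on a saturated chain carbon, ten or more bonds along the chain from a saturated ring carbon. For the measured compounds named here, two measured steps bear on chain length: a 2.5-fold higher number from compound 2 to compound 3 (0.40 log units; beyond the scatter), a modest rise in the number as the chain is shortened, and no change at the digits printed from compound 1 to compound 3 (within the scatter), no change as the chain is lengthened at the other end of the range. Chain length therefore does not move this assay in a single direction across the three compounds, and the removal of one methyl is a smaller change than either measured step.

For compound 4 the expected step of a 1.3-fold higher number from compound 3 to compound 4 (0.11 log units; within the scatter) is a small rise or none beyond the scatter, because a 2.5-fold higher number from compound 2 to compound 3 (0.40 log units; beyond the scatter) points upward on shortening while no change at the digits printed from compound 1 to compound 3 (within the scatter) shows no change. Compound 4 is thus estimated at 13 mg/kg, with a range from 5 mg/kg to 30 mg/kg.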

Compound 4, minimum effective dose: 10 mg/kg
Estimate against measurement, compound 4: 1.3-fold (0.11 log units) above, within the range that was stated.
By their numbers in this assay, from the lowest: compound 2; then compounds 1, 3 and 4 (each within the scatter of the next).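

Removing the end carbon, hydrogen in place of methyl on a saturated chain carbon, ten or more bonds along the chain from a saturated ring carbon, gives no change at the digits printed from compound 3 to compound 4 (within the scatter) in this assay and so shows that this step leaves the dose unmoved at this place. The same place with hydrogen in place of butyl gives a 2.5-fold higher number from compound 2 to compound 4 (0.40 log units; beyond the scatter) while lengthening the chain gives no change at the digits printed from compound 1 to compound 4 (within the scatter) and these steps leave compound 2 alone apart from compounds 1, 3 and 4, which stay within the scatter of one another. Nothing in the data accounts for this flat stretch or for the lower number of compound 2.

From the compounds shown here alone, whether a longer chain than that of compound 2 would carry the number lower still, and where between the chains of compound 3 and compound 2 the change sets in, remains open. Also open, going by these compounds, is how this assay responds when a carboxylic acid or an amide stands in place of the methyl ester on the shared core.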